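The source may report more compounds than this note shows. Statements on the series, on what has been measured and on what is new or still open speak of the compounds shown alone.

Compound 3, the structure `O=C(O)c1cccc(CNc2cc(C(F)(F)F)cc3[nH]ncc23)c1`, is one of three compounds that carry the same core and differ only in the group that sits on the aromatic carbon of the six-membered aromatic ring of carbon only, meta to a large group. In an assay for inhibition of Indoleamine 2,3-dioxygenase 1 (Homo sapiens), with stated times of 10 min and 60 min, tested at 100 uM (a lower number here means a weaker effect, a higher number a stronger effect of the compound at the concentration tested), compound 3 gives 17%. Compound 1, the structure `O=[N+]([O-])c1cccc(CNc2cc(C(F)(F)F)cc3[nH]ncc23)c1`, gives 69% in this assay, and compound 2, the structure `O=C(O)CNc1cccc(CNc2cc(C(F)(F)F)cc3[nH]ncc23)c1`, gives 8%. Compound 3 thus stands second of the three numbers: the step of a number 52 percentage points lower from compound 1 to compound 3 (beyond the scatter) is large, while the step of a number 9 percentage points higher from compound 2 to compound 3 (within the scatter) stays within the scatter, so compound 2 and compound 3 cannot be told apart.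

Compound 4, the structure `OC1CCCC(Nc2cccc(CNc3cc(C(F)(F)F)cc4[nH]ncc34)c2)C1`, has not yet been measured. Its change from compound 3 is (3-hydroxycyclohexyl)amino in place of carboxy on an aromatic carbon. Among the measured compounds shown here, two measured steps bear on it. The step of a number 9 percentage points higher from compound 2 to compound 3 (within the scatter) shows that an amino-linked group and a carboxy group gave the same result within the scatter, which argues for little change. The step of a number 52 percentage points lower from compound 1 to compound 3 (beyond the scatter), however, shows that the carboxy group is the weakest kind of substituent seen here, so its removal leaves room for a rise. Compound 4 is therefore expected to show a small to moderate rise, a number 11 percentage points higher from compound 3 to compound 4 (beyond the scatter), and is estimated at 28%, within a range from 8% to 55%.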

Compound 4, a percentage reported as inhibition, at one concentration (the size of the read-out at that concentration, not a potency): 2%
Estimate against measurement, compound 4: 26 percentage points above; the whole stated range lies above it.
By their numbers in this assay, from the lowest: compounds 4, 2 and 3 (each within the scatter of the next, the first and the last beyond it); then compound 1.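

Putting (3-hydroxycyclohexyl)amino in place of carboxy on this aromatic carbon gives a number 15 percentage points lower from compound 3 to compound 4 (beyond the scatter), so removing the carboxy group does not by itself raise the read-out in this assay. With a number 6 percentage points lower from compound 2 to compound 4 (within the scatter), the 3-hydroxycyclohexyl and carboxymethyl groups on the nitrogen cannot be told apart, even though one brings a six-membered non-aromatic ring and the other no ring. Among the compounds shown here, with a number 67 percentage points lower from compound 1 to compound 4 (beyond the scatter), nitro remains the only one of the four groups here that gives a high read-out, and nothing measured here accounts for this result.

Going by these compounds, it remains open whether a nitrile, an amide or an unsubstituted amine on this aromatic carbon would match nitro, and whether a plain cyclohexylamino group would match (3-hydroxycyclohexyl)amino. On these data alone, each compound also has a read-out at only one concentration, so how the effect of each compound would change at other concentrations remains open.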